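Swapping the oxazole for a fluoropyrimidine: cytotoxicity outlook

The source may report more compounds than this note shows. Statements on the series, on what has been measured and on what is new or still open speak of the compounds shown alone.

Measured in a toxicity assay on HepG2 2.2.15 cells (Homo sapiens) for cytotoxicity, read by CellTiter-Glo; a lower number here means that less compound is tolerated, a higher number that more compound is tolerated:
compound 1 `O=C1CC(c2cnco2)CN1c1cnn2c1CN(C(=O)Nc1cc(F)c(F)c(F)c1)C(C1CC1)C2` gives 139000 nM
compound 2 `O=C1OC(c2ccccc2)CN1c1cnn2c1CN(C(=O)Nc1cc(F)c(F)c(F)c1)C(C1CC1)C2` gives 7410 nM
compound 3 `O=C1CC(c2ccccc2)CN1c1cnn2c1CN(C(=O)Nc1cc(F)c(F)c(F)c1)C(Cc1ccccc1)C2` gives > 2000 nM

Compound 1 holds the highest of the two numbers shown, so it is the best tolerated of the pair. Its nearest neighbour is compound 2, and the change between them is a 19-fold lower number from compound 1 to compound 2 (1.27 log units; beyond the scatter), a large drop in tolerated concentration. Compound 3 in this assay reaches only (the limit of > 2000 nM in this assay, at which 1 of the 3 values shown sits), which is a limit of the assay and not a number.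

Compound 4 `O=C1CC(c2ncc(F)cn2)CN1c1cnn2c1CN(C(=O)Nc1cc(F)c(F)c(F)c1)C(C1CC1)C2` is not yet measured. It differs from compound 1 in one place: 5-fluoropyrimidin-2-yl in place of 1,3-oxazol-5-yl on a saturated ring carbon.

For the measured compounds named here, only one measured step exists, and it does not isolate this change. The step from compound 1 to compound 2 alters the whole five-membered ring, replacing a 2-oxopyrrolidinyl bearing an oxazolyl by an oxazolidinonyl bearing a phenyl, so it bears on the present step only loosely. Going by the values given here, no measured pair shows the exchange of one aryl group for another on the same saturated ring carbon. With the shared core and the urea kept, a step within the usual scatter is the most likely outcome, with a modest lowering not excluded.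

Compound 4 is therefore estimated at 90000 nM, with a range from 30000 nM to 200000 nM. For compound 4 the expected step is a 1.5-fold lower number from compound 1 to compound 4 (0.19 log units; within the scatter).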

Compound 4, half-maximal cytotoxic concentration: 115000 nM
For compound 4 the middle estimate is 1.3-fold (0.11 log units) below the measured one; the range from low to high includes it.
By their numbers in this assay, from the lowest: compound 2; then compounds 4 and 1 (each within the scatter of the next).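

In this assay, this saturated ring carbon, two ring bonds from the ring nitrogen, now has an exchange made in one place only: a 1.2-fold lower number from compound 1 to compound 4 (0.08 log units; within the scatter). One aromatic ring gives way to another, a five-membered ring with 5 heavy atoms to a six-membered ring with 7 that carries a fluorine, and the step stays within the scatter, so for this pair the size and make-up of the aromatic ring leave the tolerated concentration unmoved as far as this assay can tell, unlike the large step of a 19-fold lower number from compound 1 to compound 2 (1.27 log units; beyond the scatter), which alters the whole five-membered ring. Nothing in the data shown explains why this exchange leaves the number within the scatter.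

On these data alone, it remains open whether this carbon would tolerate a group that is not an aromatic ring, such as an amine or a carboxylic acid, equally well. As far as these compounds go, it is also open whether a phenyl on this carbon, with the rest of compound 1 kept, would stay with compounds 1 and 4 or fall closer to compound 2 at 7410 nM.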